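The compounds below may be only part of what the source reports. "The series", "measured", "known", "first", "only" and "open" are said of these compounds alone.

Two compounds share a core built around the same chloroquinoline-linked chain. Compound 1 `CSc1nc(OCCCNc2ccnc3cc(Cl)ccc23)c(C#N)c(-c2ccccc2)n1` and compound 2 `CSc1nc(NCCCCNc2ccnc3cc(Cl)ccc23)c(C#N)c(-c2cccc([N+](=O)[O-])c2)n1` were both tested in an ADME assay on CCRF-CEM cells (Homo sapiens) for inhibition, read by cell counting; a lower number here means a stronger inhibitor, a higher number a weaker inhibitor. In this assay compound 1 gives 3300 nM, and in the same assay compound 2 gives 2100 nM. These two numbers lie within the scatter of each other, so compound 2 is not set apart from compound 1 on the evidence so far.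

Compound 3 `COc1cc(-c2nc(SC)nc(NCCCCNc3ccnc4cc(Cl)ccc34)c2C#N)cc(OC)c1OC` is the next candidate. It differs from compound 2 in one place: 3,4,5-trimethoxyphenyl in place of 3-nitrophenyl on an aromatic carbon. Among the measured compounds shown here, no measured pair shows this kind of exchange, so there is nothing to anchor the size of the step. Compound 3 is therefore expected to come out close to compound 2, with a step of a 1.4-fold lower number from compound 2 to compound 3 (0.15 log units; within the scatter) that may lean toward a lower number but need not exceed the scatter. Compound 3 is estimated at 1500 nM, with a range from 400 nM to 6000 nM.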

Compound 3, half-maximal inhibitory concentration: 3600 nM
Estimate against measurement, compound 3: 2.4-fold (0.38 log units) below; the range from low to high includes it.
By their numbers in this assay, from the lowest: compounds 2, 1 and 3 (each within the scatter of the next).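

In this assay, 3,4,5-trimethoxyphenyl in place of 3-nitrophenyl, on the aromatic carbon ortho to a cyano group, gives a 1.7-fold higher number from compound 2 to compound 3 (0.23 log units; within the scatter). This position therefore carries a group of 12 heavy atoms with three oxygens, or one of 9 heavy atoms with a nitrogen and two oxygens, and the two compounds are not told apart in this read-out. Nothing measured here offers a reason for this result.

From the compounds shown here alone, it remains open whether a phenyl group bearing an amine or a carboxylic acid at this position would give a step beyond the scatter. Compound 1 differs from compound 2 in more than one place, so the effects of its oxygen-linked chain and its unsubstituted phenyl cannot be separated, and a longer chain also remains untested among these compounds.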